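Nitro-substituted bis-benzylidene cyclohexanones: a para-chloro variant

The source may hold more compounds than are shown below. What is called first, only, known or untested is meant among the compounds shown, and "the series" means these compounds.

Measured so far:
compound 1, `Cc1ccc(/C=C2\CCC/C(=C\c3ccc([N+](=O)[O-])cc3)C2=O)cc1`: 8160 nM
compound 2, `O=C1/C(=C/c2ccc(F)cc2)CCC/C1=C\c1cccc([N+](=O)[O-])c1`: 16300 nM
compound 3, `O=C1/C(=C/c2ccc(F)cc2)CCC/C1=C\c1ccccc1[N+](=O)[O-]`: 8400 nM

In a functional assay on L1210 cells (Mus musculus) for cytotoxicity, with a stated time of 48 h (on this read-out lower numbers stand for stronger inhibition and higher numbers for weaker inhibition), compound 1 gives 8160 nM. This is the lowest of the three numbers, yet the gap to compound 3 and the gap to compound 2 both sit within the usual scatter of repeated runs, so the three compounds cannot be separated on these data. Within the data shown here, no step between compounds that differ in a single place is available in this set; compound 2 and compound 3 each differ from compound 1 in more than one place, and only their values can be compared, not a counted change.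

Compound 4, `O=C1/C(=C/c2ccc(Cl)cc2)CCC/C1=C\c1ccc([N+](=O)[O-])cc1`, has not yet been run in this assay. Against compound 1 the change is chloro in place of methyl on an aromatic carbon, para to a large group, the 4-methylphenyl becoming 4-chlorophenyl. Nothing in the measured set speaks to this exchange. With the three numbers so close together, the step from compound 1 to compound 4 is expected to be small, a 1.1-fold lower number from compound 1 to compound 4 (0.04 log units; within the scatter), with no direction beyond the scatter predicted. Compound 4 is therefore estimated at 7500 nM, within 3000 nM to 18000 nM.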

Compound 4, half-maximal inhibitory concentration: 9410 nM
Compound 4: the middle estimate sits 1.3-fold (0.10 log units) below what was measured; measured number inside the range.
By their numbers in this assay, from the lowest: compounds 1, 3, 4 and 2 (each within the scatter of the next).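

In this assay, among these compounds, the exchange of 4-methylphenyl for 4-chlorophenyl gives the first step between compounds that differ in one place: a 1.2-fold higher number from compound 1 to compound 4 (0.06 log units; within the scatter). The earlier compounds shown here allowed only a side-by-side reading of values, whereas this pair isolates one group on an aromatic carbon, para to a large group, with the rest of the core of compound 1 held constant, and on this read-out methyl and chloro cannot be told apart at that place. No separate measurement bears on this exchange, so the step stands as a number without an explanation.

Among the compounds shown here, still open is whether a group of another kind at the same place, such as an amine, a carboxylic acid or a longer chain, would give a step beyond the scatter, since methyl and chloro are the only two groups compared there by a single-place step. From the compounds shown here alone, the nitro group also remains untested by any such step, so replacing it with a nitrile or an amine is an open comparison on the shared core.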